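Ring amine nitrogen substitution: expectation for compound 4

This account rests on a few compounds, and the source may have more. Where it says the series, first, only, none or still open, it means among the compounds named here.

Measured compounds:
Compound 1 `Cc1cccc2c1nc(COc1ccc(Cl)cc1)n2CCCC1CCNCC1` gives 335 nM.
Compound 2 `Cc1cccc2c1nc(COc1ccc(Cl)cc1)n2CCCC1CCN(CCC(C)C)CC1` gives 11 nM.
Compound 3 `CCOC(=O)CCCN1CCC(CCCn2c(COc3ccc(Cl)cc3)nc3c(C)cccc32)CC1` gives 29 nM.

All values come from an assay on AV12 cells for binding affinity to Neuropeptide Y receptor type 1 (Homo sapiens); a lower number here means a stronger inhibitor, a higher number a weaker inhibitor. Compound 1 stands highest of the three numbers; the steps from it read a 12-fold lower number from compound 1 to compound 3 (1.06 log units; beyond the scatter) and a 30-fold lower number from compound 1 to compound 2 (1.48 log units; beyond the scatter), both large. Compound 4 `Cc1cccc2c1nc(COc1ccc(Cl)cc1)n2CCCC1CCN(CC(=O)O)CC1` differs from compound 1 by carboxymethyl in place of hydrogen on an amine nitrogen in a ring. The two measured steps from compound 1 replace the same hydrogen and both lower the number strongly, so they bear on this step. The entering carboxymethyl, however, carries a hydrogen-bond donor, which neither isopentyl nor 3-(ethoxycarbonyl)propyl does, so a lowering smaller than either of those two steps from compound 1 is expected: a 2.2-fold lower number from compound 1 to compound 4 (0.35 log units; beyond the scatter). Compound 4 is estimated at 150 nM, with a range from 40 nM to 600 nM.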

Compound 4, inhibition constant: 2190 nM
Estimate against measurement, compound 4: 15-fold (1.16 log units) below, outside the stated range (above it).
By their numbers in this assay, from the lowest: compound 2; then compound 3; then compound 1; then compound 4.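

In this assay, going by these compounds alone, carboxymethyl on the amine nitrogen gives a 6.5-fold higher number from compound 1 to compound 4 (0.82 log units; beyond the scatter) and is the only step from compound 1 that raises the number, so replacing this hydrogen does not lower it in every case. The entering group sets the direction of the change, with a 76-fold higher number from compound 3 to compound 4 (1.88 log units; beyond the scatter) and a 200-fold higher number from compound 2 to compound 4 (2.30 log units; beyond the scatter) marking the spread among substituents at this nitrogen. No measurement here accounts for this spread.

Still open, from the compounds shown here alone, is whether (ethoxycarbonyl)methyl, or a longer chain ending in a carboxylic acid, would track compound 3 or compound 4.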